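The compounds below may be only part of what the source reports. "The series", "measured", "known", "first", "only" and "open" are said of these compounds alone.

Measured so far in a physicochemical assay for lipophilicity, at pH 7.4; on this read-out higher numbers stand for higher lipophilicity and lower numbers for lower lipophilicity:
- compound 1 `CCNC(=O)c1cc(C(=O)NC)c(=O)n(Cc2ccccc2)c1` gives 3
- compound 2 `CNC(=O)c1cc(C(=O)NCC(C)C)cn(Cc2ccccc2)c1=O` gives 4.3

Of these two compounds, compound 2 stands higher, at 4.3. Compound 3 `CNC(=O)c1cc(C(=O)NCCC(C)C)cn(Cc2ccccc2)c1=O` has not yet been measured. Compared with compound 2, it carries isobutyl in place of isopropyl on a saturated chain carbon bound to an amide-type nitrogen, with isobutyl in place of isopropyl on a saturated chain carbon bound to an amide-type nitrogen.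

A single measured step bears on this change. It is a number 1.30 log units higher from compound 1 to compound 2 (beyond the scatter), a large rise beyond the scatter, with isopropyl in place of methyl at the same kind of place. The present swap is the smaller one in size of group, so a rise in the same direction but of lesser size is expected, namely a number 0.50 log units higher from compound 2 to compound 3 (beyond the scatter). For compound 3 the estimated value in this assay is 4.8, with an expected range from 4.4 to 5.2.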

Compound 3, distribution coefficient: 4.8
Compound 3: the middle estimate sits on the measured number at the digits printed; low and high end bracket the measured number.
By their numbers in this assay, from the lowest: compound 1; then compound 2; then compound 3.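

In this assay, isobutyl in place of isopropyl on a saturated chain carbon bound to an amide-type nitrogen gives a number 0.50 log units higher from compound 2 to compound 3 (beyond the scatter), so the number does not level off once isopropyl is reached. The step is modest, whereas the earlier step, a number 1.30 log units higher from compound 1 to compound 2 (beyond the scatter), was large, so the larger of the two rises came first in this short series. Over the whole series the change amounts to a number 1.80 log units higher from compound 1 to compound 3 (beyond the scatter), and among these three compounds the number climbs as the group at this place grows, with none going against that order.

Going by these compounds, whether a longer chain would extend the rise, and where an amine or a carboxylic acid at the same place would fall, stays open. Nothing measured here explains the size of either step.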